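The source may hold more compounds than are shown below. What is called first, only, known or untested is meant among the compounds shown, and "the series" means these compounds.

Working notes on the series. In an ADME assay on MOLT-3 cells (Homo sapiens) for cytotoxicity, with a stated time of 7 days (a higher number here means that more compound is tolerated, a lower number that less compound is tolerated), compound 3 `CCCCCCCCSc1nc(N)nc2c1ncn2/C=C1/CC1(CO)CO` gives only a limit of the assay, > 20000 nM. Compound 1 `CCCCCCCCOc1nc(N)nc2c1ncn2/C=C1/CC1(CO)CO` likewise reports only a limit, > 20000 nM. Compound 2 `Nc1nc(NCc2ccccc2)c2ncn(/C=C3/CC3(CO)CO)c2n1` also sits at a limit, > 20000 nM. All three values rest on (the limit of > 20000 nM in this assay, at which 3 of the 3 values shown sit), so the steps among them cannot be read: the step that the two limits leave unreadable from compound 1 to compound 2 is unreadable, as are a step that the two limits leave unreadable from compound 1 to compound 3 and a step that the two limits leave unreadable from compound 2 to compound 3. Compound 3 therefore stands nowhere in particular on the numbers shown; it shares the common limit with the other two.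

Compound 4 `Nc1nc(SC2CCCC2)c2ncn(/C=C3/CC3(CO)CO)c2n1` is not yet measured. It differs from compound 3 by cyclopentyl in place of octyl on a sulfur. None of the three measured steps bears on this change in a readable way: each of them swaps the whole group on the aromatic carbon, and each is hidden by the limit. No change from octyl to a ring on the sulfur has been measured in the series. The step that the limit leaves unreadable from compound 3 to compound 4 is expected to be none beyond the scatter, if a number appears at all. For compound 4 the estimate in this assay is 25000 nM, with a range from 12000 nM to 60000 nM, and a limit is the likelier report.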

Compound 4, half-maximal cytotoxic concentration: > 20000 nM
Compound 4 was reported as a limit (the forecaster's own chance of this, stated with the estimate: 85%); the middle value does not contradict the limit.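

No new step can be read in this assay: compound 4 reports a limit, as do compound 1, compound 2 and compound 3, so its steps to all three stay unreadable, and the series rests on one shared value: the limit of > 20000 nM in this assay, at which 4 of the 4 values shown sit.

The compounds shown leave open whether cyclopentylsulfanyl, octylsulfanyl, octyloxy and benzylamino on the shared core differ at all in this assay.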